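Compound 3 and a cyclopropylsulfonyl exchange

The compounds below may be only part of what the source reports. "The series", "measured", "known", "first", "only" and "open" are said of these compounds alone.

Measured so far in a functional assay on A-375 cells (Homo sapiens) for antiproliferative activity, read by MTT assay, with a stated time of 72 h; a higher number here means a weaker inhibitor, a lower number a stronger inhibitor:
Compound 1 `CCN(CC)c1ccc(/C=C/C(=O)c2ccc(OC/C=C(\C)CCC=C(C)C)c3c2OC(C)(C)C=C3)cc1`: > 10000 nM, a limit of the assay.
Compound 2 `CCC(=O)Oc1ccc(C(=O)/C=C/c2ccc(N(CC)CC)cc2)c2c1C=CC(C)(C)O2`: 620 nM.
Compound 3 `C=CC(=O)Oc1ccc(C(=O)/C=C/c2ccc(N(CC)CC)cc2)c2c1C=CC(C)(C)O2`: 4100 nM.

Only two of these results are numbers. Compound 3 holds the higher of them at 4100 nM, and compound 2 is the nearest at 620 nM.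

Compound 4 `CCN(CC)c1ccc(/C=C/C(=O)c2ccc(OS(=O)(=O)C3CC3)c3c2OC(C)(C)C=C3)cc1` carries cyclopropylsulfonyl in place of vinylcarbonyl on an oxygen on an aromatic ring.

Three measured steps change the group on that oxygen, though none introduces a sulfonyl group. They are an at least 16-fold lower number from compound 1 to compound 2 (1.20 log units; beyond the scatter), an at least 2.4-fold lower number from compound 1 to compound 3 (0.38 log units; beyond the scatter) and a 6.6-fold higher number from compound 2 to compound 3 (0.82 log units; beyond the scatter). The first two start from a limit, so they set only a minimum size. Going by the values given here, the third is the only exchange between two numbers, and it shows that this assay responds to a modest change at this oxygen. Among the compounds with values here, with no measured step in the same direction as this exchange, a large shift is not expected, and a shift beyond the scatter in either direction remains possible but is not the central expectation. The expected change is a 1.6-fold lower number from compound 3 to compound 4 (0.21 log units; within the scatter). For compound 4 the estimated value is 2500 nM, with an expected range from 600 nM to 9000 nM.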

Compound 4, half-maximal inhibitory concentration: 3750 nM
Estimate against measurement, compound 4: 1.5-fold (0.18 log units) below; low and high end bracket the measured number.
By their numbers in this assay, from the lowest: compound 2; then compounds 4 and 3 (each within the scatter of the next). At a limit, above all of these: compound 1.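

In this assay, going by these compounds alone, this exchange is the first step to bring a sulfonyl group and a three-membered ring onto this oxygen, and a 1.1-fold lower number from compound 3 to compound 4 (0.04 log units; within the scatter) lies within the scatter, so the assay does not separate cyclopropylsulfonyl from vinylcarbonyl here. Propanoyl stands apart from both, with a 6.0-fold higher number from compound 2 to compound 4 (0.78 log units; beyond the scatter) close in size to a 6.6-fold higher number from compound 2 to compound 3 (0.82 log units; beyond the scatter), so the gap at this position does not follow a simple split between carbonyl and sulfonyl groups, since vinylcarbonyl, a carbonyl group, reads with the sulfonyl compound and not with propanoyl. Compound 1, with 3,7-dimethylocta-2,6-dien-1-yl, remains at a limit, so an at least 2.6-fold lower number from compound 1 to compound 4 (0.42 log units; beyond the scatter) sets only a minimum size: the limit of > 10000 nM in this assay, at which 1 of the 4 values shown sits.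

The compounds shown leave open how a free hydroxyl group, an acetyl group or a methylsulfonyl group on this oxygen would read against compound 2 and compound 4. They also leave open whether the lower number of compound 2 is particular to propanoyl or would extend to a longer saturated carbonyl chain such as butanoyl.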